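Trifluoromethyl in place of fluoro: one more growth-inhibition step

A few compounds are considered here, and "the series" means these few. Any claim that something is new, unique, unknown or untested is made for them only; others in the source may bear on it.

Measured in a functional assay on ZR-75-1 cells (Homo sapiens) for inhibition, read by sulforhodamine B assay (on this read-out lower numbers stand for stronger inhibition of growth and higher numbers for weaker inhibition of growth), so far:
compound 1 `Oc1cccc2[nH]c(-c3ccc(-c4ccc(-c5ccccc5)cc4)cc3)nc12` gives 35600 nM
compound 2 `Oc1cccc2[nH]c(-c3ccc(-c4ccc(-c5ccc(F)cc5)cc4)cc3)nc12` gives 6320 nM

Of these two, compound 2 holds the lower number and so shows the stronger inhibition of growth. Compound 3 `Oc1cccc2[nH]c(-c3ccc(-c4ccc(-c5ccc(C(F)(F)F)cc5)cc4)cc3)nc12` differs from it by trifluoromethyl in place of fluoro on an aromatic carbon and carries trifluoromethyl in place of fluoro on an aromatic carbon, para to a large group. Among the compounds with values here, only one measured step bears on this change: a 5.6-fold lower number from compound 1 to compound 2 (0.75 log units; beyond the scatter), which came with fluoro in place of hydrogen on an aromatic carbon. A single step sets no trend, so only a small move toward a lower number in this assay is expected. The expected change is a 1.6-fold lower number from compound 2 to compound 3 (0.20 log units; within the scatter) and may not clear the scatter. For compound 3 the estimated value is 4000 nM, with an expected range from 1200 nM to 14000 nM.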

Compound 3, concentration for 50% growth inhibition: 5110 nM
For compound 3 the middle estimate is 1.3-fold (0.11 log units) below the measured one, and the stated range covers the measured number.
By their numbers in this assay, from the lowest: compounds 3 and 2 (each within the scatter of the next); then compound 1.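

In this assay, trifluoromethyl and fluoro at this position, para to a large group, cannot be told apart: the step reads (a 1.2-fold lower number from compound 2 to compound 3 (0.09 log units; within the scatter)). Measured against hydrogen, however, trifluoromethyl gives a step beyond the scatter (a 7.0-fold lower number from compound 1 to compound 3 (0.84 log units; beyond the scatter)), so the lower number seen with fluoro is now also seen with a second, larger group of four heavy atoms rather than one. No measurement at hand explains this result.

The compounds shown leave open whether the lower number extends to groups of another kind at this position, such as an amine, a carboxylic acid or a methoxy group, as only hydrogen, fluoro and trifluoromethyl appear there. They also leave open whether the same groups would behave alike elsewhere on the terminal ring.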